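The compounds below may be only part of what the source reports. "The series", "measured", "known", "first", "only" and "open" are said of these compounds alone.

Measured in a physicochemical assay for solubility, with a stated time of 18 h, at pH 7.4; on this read-out lower numbers stand for lower solubility and higher numbers for higher solubility:
compound 1 `COc1ccc(F)cc1CNCCCNc1ccnc2cc(Cc3ccc(C#N)cc3)ccc12` gives 4200 nM
compound 2 `COc1cccc(CNCCCNc2ccnc3cc(Cc4cccc(C(F)(F)F)c4)ccc23)c1O` gives 4200 nM
compound 3 `COc1cccc(CNCCCNc2ccnc3cc(Cc4ccc(C#N)cc4)ccc23)c1O` gives 4200 nM

Compound 1 stands level with compounds 2 and 3 at the digits shown. The step in this assay from compound 1 to compound 3 is no change at the digits printed from compound 1 to compound 3 (within the scatter), and from compound 2 to compound 3 it is no change at the digits printed from compound 2 to compound 3 (within the scatter).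

Compound 4 `COc1ccc(F)cc1CNCCCNc1ccnc2cc(Oc3ccccc3)ccc12` differs from compound 1 by phenoxy in place of 4-cyanobenzyl on an aromatic carbon. For the measured compounds named here, no measured step exchanges the group on this aromatic carbon for phenoxy; the nearest comparison is no change at the digits printed from compound 2 to compound 3 (within the scatter), which swapped the aryl attached to that saturated chain carbon without effect. Compound 4 is therefore expected to show a step of no change at the digits printed from compound 1 to compound 4 (within the scatter), no change beyond the scatter. Compound 4 is estimated at 4200 nM, range 1800 nM to 10000 nM.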

Compound 4, solubility: 14500 nM
Estimate against measurement, compound 4: 3.5-fold (0.54 log units) below; measured number outside the range, above it.
By their numbers in this assay, from the lowest: compounds 1, 2 and 3 (each within the scatter of the next); then compound 4.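

In this assay, phenoxy in place of 4-cyanobenzyl on this aromatic carbon gives a 3.5-fold higher number from compound 1 to compound 4 (0.54 log units; beyond the scatter) and so moves the read-out beyond the scatter, whereas the aryl swap on the saturated chain carbon gave no change at the digits printed from compound 2 to compound 3 (within the scatter) and did not. For the compounds shown here, the single step replaces the whole group, so the oxygen link and the loss of the nitrile cannot be separated. No measurement bears on why the number rises.

Open, from the compounds shown here alone, is whether 4-cyanophenoxy or an unsubstituted benzyl on this carbon would follow compound 4 or compound 1. Also open, going by these compounds, is whether the same exchange holds with the 2-hydroxy-3-methoxyphenyl group of compound 3.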